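The source may report more compounds than this note shows. Statements on the series, on what has been measured and on what is new or still open speak of the compounds shown alone.

Measured so far in an ADME assay on HepG2 cells (Homo sapiens) for cytotoxicity, read by neutral red uptake, with a stated time of 24 h (a higher number here means a weaker inhibitor, a lower number a stronger inhibitor), for the series:
- compound 1 (`CC(=O)Oc1c(C(C)C)cc2c3c1OC(=O)[C@@]31CCCC(C)(C)[C@@H]1CC2`) gives 294000 nM
- compound 2 (`CCC(=O)Oc1c(C(C)C)cc2c3c1OC(=O)[C@@]31CCCC(C)(C)[C@@H]1CC2`) gives 196000 nM

Among the compounds with values here, compound 2 cannot be separated from compound 1, the only other measured compound. Compound 3 (`CCCC(=O)Oc1c(C(C)C)cc2c3c1OC(=O)[C@@]31CCCC(C)(C)[C@@H]1CC2`) differs from compound 2 by methyl in place of hydrogen on a saturated chain carbon, two bonds along the chain from a carbonyl carbon in going from ethyl to propyl. Within the data shown here, the one measured step bearing on this, also methyl in place of hydrogen but on a saturated chain carbon bound to a carbonyl carbon, is a 1.5-fold lower number from compound 1 to compound 2 (0.18 log units; within the scatter) and gives no sign of a real shift. No step beyond the scatter is therefore expected in this assay for this change. The expected step is small (a 1.2-fold lower number from compound 2 to compound 3 (0.06 log units; within the scatter)). Compound 3 is expected at 170000 nM (estimated range 85000 nM to 320000 nM).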

Compound 3, half-maximal inhibitory concentration: 56100 nM
Compound 3: middle estimate off by 3.0-fold (0.48 log units), on the high side; the measured number lies below the stated range.
By their numbers in this assay, from the lowest: compound 3; then compounds 2 and 1 (each within the scatter of the next).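

In this assay, within the data shown here, methyl in place of hydrogen on a saturated chain carbon, two bonds along the chain from a carbonyl carbon, gives a 3.5-fold lower number from compound 2 to compound 3 (0.54 log units; beyond the scatter) and is the first step beyond the scatter. The larger change in the same chain gives a 5.2-fold lower number from compound 1 to compound 3 (0.72 log units; beyond the scatter) and so sets compound 3 apart from both shorter chains. Nothing measured here accounts for this step. As far as these compounds go, whether a longer chain extends the step remains open. So does the effect of an amine or a carboxylic acid at the end of the propyl chain.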